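Swapping the pivalate for a pyrrolidinylacetate ester

The compounds below may be only part of what the source reports. "The series", "measured", "known", "first", "only" and "open" are said of these compounds alone.

In an ADME assay on L6 cells (Rattus norvegicus) for cytotoxicity, with a stated time of 72 h (a lower number here means a stronger inhibitor, a higher number a weaker inhibitor), compound 3, `CN(C)C12CC(OC(=O)C(C)(C)C)C(C(c3ccccc3)C1)C(c1ccccc1)C2`, gives 5060 nM, the lowest of the two numbers reported. Compound 1, `O=C(CN1CCCC1)OC1CC2(N3CCCCC3)CC(c3ccccc3)C1C(c1ccccc1)C2`, gives 16400 nM in this assay, a number that stands beyond the scatter from that of compound 3. For compound 2, `CC(=O)OC1CC2(N(C)C)CC(c3ccccc3)C1C(c1ccccc1)C2`, the result in this assay is "not determined" (no result reported). The next compound, compound 4, `CN(C)C12CC(OC(=O)CN3CCCC3)C(C(c3ccccc3)C1)C(c1ccccc1)C2`, is not yet measured; it differs from compound 3 in one place: (pyrrolidin-1-yl)methyl in place of tert-butyl on a carbonyl carbon. For the measured compounds named here, no step between measured compounds is available for this change, so the expectation rests on compound 3 alone, and the step from compound 3 to compound 4 is expected to be a 2.4-fold higher number from compound 3 to compound 4 (0.38 log units; beyond the scatter), towards a weaker inhibitor. Compound 4 is therefore estimated at 12000 nM, with a range from 5000 nM to 30000 nM.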

Compound 4, half-maximal inhibitory concentration: 32700 nM
Beside the measured number, compound 4's estimate is 2.7-fold (0.44 log units) below it; measured number above the stated range.
By their numbers in this assay, from the lowest: compound 3; then compounds 1 and 4 (each within the scatter of the next).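

In this assay, for the compounds shown here, the first direct reading of (pyrrolidin-1-yl)methyl in place of tert-butyl on a carbonyl carbon gives a 6.5-fold higher number from compound 3 to compound 4 (0.81 log units; beyond the scatter) and so moves towards a weaker inhibitor. With this ester in place, dimethylamino in place of piperidin-1-yl on a saturated ring carbon gives a 2.0-fold higher number from compound 1 to compound 4 (0.30 log units; within the scatter) and does not separate the two compounds. Nothing measured here explains either step.

The compounds shown leave open whether morpholin-4-ylmethyl or a longer chain carrying the pyrrolidine would behave alike on the carbonyl carbon. They also leave open whether the step from tert-butyl holds with piperidin-1-yl on the core.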